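From a nitrooxy chain to a cyano-bearing ring

The source may report more compounds than this note shows. Statements on the series, on what has been measured and on what is new or still open speak of the compounds shown alone.

- compound 1 `COC(=O)C1=C(C)N=C(C)/C(=C(/O)OC)C1c1cccc(OCCO[N+](=O)[O-])c1` gives 750 nM
- compound 2 `COC(=O)C1=C(C)N=C(C)/C(=C(/O)OC)C1c1ccccc1OCc1nonc1C` gives 41 nM
- compound 3 `COC(=O)C1=C(C)N=C(C)/C(=C(/O)OC)C1c1ccccc1OCc1no[n+]([O-])c1C` gives 43 nM

These values come from a functional assay (aorta) with Rattus norvegicus as the target, in the presence of a further agent that is not named here (on this read-out higher numbers stand for an effect only at larger amounts of compound and lower numbers for an effect already at smaller amounts), and compound 1 has the highest number of the three, so it needs the largest amount to act. Compound 2 and compound 3 both lie well below it, by more than the usual scatter.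

The unmeasured compound 4 `COC(=O)C1=C(C)N=C(C)/C(=C(/O)OC)C1c1cccc(OCc2nonc2C#N)c1` keeps the core of compound 1 but changes its side chain: 4-cyano-1,2,5-oxadiazol-3-yl in place of (nitrooxy)methyl on a saturated chain carbon bound to an oxygen on an aromatic ring. A 4-cyano-1,2,5-oxadiazol-3-yl group thus replaces (nitrooxy)methyl on a saturated chain carbon bound to an oxygen on an aromatic ring.

Among the measured compounds shown here, only one measured step bears on this, and only indirectly. The change a 1.0-fold higher number from compound 2 to compound 3 (0.02 log units; within the scatter) alters a five-membered aromatic ring with 3 hetero atoms and stays within the scatter. Compound 4 also carries such a ring, as does compound 2 with its 41 nM value, so a move toward lower numbers is expected. For the measured compounds named here, no measured step connects compound 1 directly to a compound with this ring, so only part of that gap is expected to carry over.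

The expected change is a 4.4-fold lower number from compound 1 to compound 4 (0.64 log units; beyond the scatter) in this assay, with wide uncertainty. For compound 4 the estimate is 170 nM, with an expected range from 35 nM to 800 nM as its limits.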

Compound 4, half-maximal effective concentration: 310 nM
The estimate for compound 4 lay 1.8-fold (0.26 log units) below the measured number; measured number inside the range.
By their numbers in this assay, from the lowest: compounds 2 and 3 (each within the scatter of the next); then compound 4; then compound 1.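

In this assay, the side chain of compound 1 gives way to a ring-bearing group, and the result is a 2.4-fold lower number from compound 1 to compound 4 (0.38 log units; beyond the scatter), a modest step but the first direct link between a nitrooxy chain and a five-membered aromatic ring with 3 hetero atoms at this place, on a saturated chain carbon bound to an oxygen on an aromatic ring. The step shows that the (nitrooxy)methyl group can leave this place with no rise in the number: compound 4 acts at a smaller amount despite carrying no nitrooxy group, whereas the earlier step from compound 2 to compound 3 only altered the ring itself. Nothing measured here explains why the number falls.

From the compounds shown here alone, it remains open whether the ring or its nitrile accounts for the step, and a carboxylic acid or an amine in place of the nitrile on the same ring would help to separate the two. Compound 4 also differs from compound 2 and compound 3 in more than one place, so the gap between their numbers cannot be assigned to any single change.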